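A few compounds are considered here, and "the series" means these few. Any claim that something is new, unique, unknown or untested is made for them only; others in the source may bear on it.

Three compounds share one core and differ only in the group attached to a nitrogen on an aromatic ring. Compound 1 `O=C(Nc1cccc(/C=C/C(=O)c2nc3ccccc3[nH]2)c1)c1cccc(Cl)c1` gives in a functional assay on HCT-116 cells (Homo sapiens) for antiproliferative activity, read by MTT assay, with a stated time of 48 h (a lower number here means a stronger inhibitor, a higher number a weaker inhibitor), a value of 1120 nM. Compound 2 `O=C(Nc1cccc(/C=C/C(=O)c2nc3ccccc3[nH]2)c1)c1ccc(Br)cc1` gives 2230 nM in this assay, and compound 3 `COc1ccc(C(=O)Nc2cccc(/C=C/C(=O)c3nc4ccccc4[nH]3)c2)cc1` gives 4880 nM. The step of a 2.0-fold higher number from compound 1 to compound 2 (0.30 log units; within the scatter) stays within the scatter, whereas a 4.4-fold higher number from compound 1 to compound 3 (0.64 log units; beyond the scatter) and a 2.2-fold higher number from compound 2 to compound 3 (0.34 log units; beyond the scatter) both go beyond it, so compound 3 stands highest of the three numbers and is the weakest inhibitor measured here.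

Compound 4 `Cc1ccccc1S(=O)(=O)Nc1cccc(/C=C/C(=O)c2nc3ccccc3[nH]2)c1` arises from compound 3 by a change in the same place: (2-methylphenyl)sulfonyl in place of (4-methoxyphenyl)carbonyl on a nitrogen on an aromatic ring. Among the compounds with values here, no measured step replaces a carbonyl by a sulfonyl; the two steps that end at compound 3, a 4.4-fold higher number from compound 1 to compound 3 (0.64 log units; beyond the scatter) and a 2.2-fold higher number from compound 2 to compound 3 (0.34 log units; beyond the scatter), only exchange the substituent on the aryl ring and show that such exchanges move this assay modestly. The new change is larger than those, so the numbers give only a weak guide. The step of a 1.4-fold lower number from compound 3 to compound 4 (0.14 log units; within the scatter) is therefore expected to be small, in no firm direction, with wide uncertainty. For compound 4 the estimate in this assay is 3500 nM, within a range from 900 nM to 14000 nM.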

Compound 4, half-maximal inhibitory concentration: 955 nM
For compound 4 the middle estimate is 3.7-fold (0.56 log units) above the measured one, within the range that was stated.
By their numbers in this assay, from the lowest: compounds 4, 1 and 2 (each within the scatter of the next, the first and the last beyond it); then compound 3.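

In this assay, within the data shown here, this nitrogen on an aromatic ring tolerates a sulfonyl link as well as a carbonyl link, something the earlier compounds could not show, since they only exchanged groups on the aryl ring; the new change gives a 5.1-fold lower number from compound 3 to compound 4 (0.71 log units; beyond the scatter). The effect depends on the starting compound: a 2.3-fold lower number from compound 2 to compound 4 (0.37 log units; beyond the scatter) also lies beyond the scatter but is smaller, while a 1.2-fold lower number from compound 1 to compound 4 (0.07 log units; within the scatter) stays within it, so the (2-methylphenyl)sulfonyl group cannot be told apart from the (3-chlorophenyl)carbonyl group in this assay. Nothing available explains these differences in size or gives a reason for any of these steps.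

The compounds shown leave open how much of the change belongs to the sulfonyl link and how much to the aryl group it carries, as both differ at once; a (4-methoxyphenyl)sulfonyl group on the same nitrogen would separate the two. Also open, as far as these compounds go, is how this position responds to a group with no aromatic ring, such as methylsulfonyl or acetyl, or to an aryl ring carrying an amine or a carboxylic acid.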